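Replacing 4-cyanophenyl with 3-(hydroxymethyl)phenyl in compound 3

The compounds below may be only part of what the source reports. "The series", "measured", "known", "first", "only" and "open" are said of these compounds alone.

Measured in a functional assay on MCF7 cells (Homo sapiens) for inhibition, read by sulforhodamine B assay, with a stated time of 48 h, tested at 50 uM; on this read-out higher numbers stand for more inhibition of growth at the one concentration tested and lower numbers for less inhibition of growth:
- compound 1 `CCCOc1ccc([C@@H]2CC(=O)c3cc(CC=C(C)C)c(OC)cc3O2)cc1` with 60%
- compound 2 `COc1ccc([C@@H]2C/C(=N/OCc3cn(-c4ccc(C(=O)c5ccccc5)cc4)nn3)c3cc(CC=C(C)C)c(OC)cc3O2)cc1` with 41%
- compound 3 `COc1ccc([C@@H]2C/C(=N/OCc3cn(-c4ccc(C#N)cc4)nn3)c3cc(CC=C(C)C)c(OC)cc3O2)cc1` with 40%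

Compound 3 at 40% cannot be told apart from compound 2 , while compound 1 at 60% stands clearly higher. The next compound to be tested is compound 4 `COc1ccc([C@@H]2C/C(=N/OCc3cn(-c4cccc(CO)c4)nn3)c3cc(CC=C(C)C)c(OC)cc3O2)cc1`. It differs from compound 3 in one place: 3-(hydroxymethyl)phenyl in place of 4-cyanophenyl on an aromatic nitrogen. In short, 3-(hydroxymethyl)phenyl stands in place of 4-cyanophenyl on an aromatic nitrogen.

Among the measured compounds shown here, the one measured step that bears on this is a number 1 percentage points lower from compound 2 to compound 3 (within the scatter). It put cyano in place of benzoyl on an aromatic carbon, and the number barely moved. For the measured compounds named here, no measured compound carries a hydroxymethyl group, so this evidence is thin, and no change beyond the scatter is expected in this assay. The expected step is a number 2 percentage points higher from compound 3 to compound 4 (within the scatter). For compound 4 the estimated value is 42%, with an expected range from 28% to 56%.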

Compound 4, percent growth inhibition at one concentration: 42%
Beside the measured number, compound 4's estimate shows no gap at the digits printed; the range from low to high includes it.
By their numbers in this assay, from the lowest: compounds 3, 2 and 4 (each within the scatter of the next); then compound 1.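

In this assay, exchanging 4-cyanophenyl for 3-(hydroxymethyl)phenyl on the aromatic nitrogen gives a number 2 percentage points higher from compound 3 to compound 4 (within the scatter). This is a larger change in the make-up of the group than the size of the step suggests: the triple bond leaves and a hydrogen-bond donor enters, with the heavy-atom count unchanged, yet the read-out gives no sign of a real difference at this one tested concentration. Nothing available accounts for this lack of a clear change. Going by these compounds, whether an amine or a carboxylic acid on this aromatic ring would move the number beyond the scatter remains open. So does whether a longer chain of carbon atoms, in place of the whole aromatic ring on that nitrogen, would do so.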